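Hydrolytic stability series: amide nitrogen substituents

This account rests on a few compounds, and the source may have more. Where it says the series, first, only, none or still open, it means among the compounds named here.

Measured compounds:
- compound 1 `COc1cccc(CNC(=O)c2ccc(Oc3ccc(C)cc3)cc2)c1`: > 1000 h
- compound 2 `Cc1ccc(Oc2ccc(C(=O)NCC3CCCCC3)cc2)cc1`: > 1000 h
- compound 3 `CNC(=O)c1ccc(Oc2ccc(C)cc2)cc1`: > 1000 h

In a physicochemical assay for pharmacokinetics, at pH 4 (on this read-out higher numbers stand for a longer-lived compound and lower numbers for a shorter-lived compound), compound 1 gives > 1000 h, which is a limit of the assay and not a number. Compound 2 gives > 1000 h, also a limit. Compound 3 gives > 1000 h, again a limit. All three values sit at the limit of > 1000 h in this assay, at which 3 of the 3 values shown sit, so the steps a step that the two limits leave unreadable from compound 1 to compound 2, a step that the two limits leave unreadable from compound 1 to compound 3 and a step that the two limits leave unreadable from compound 2 to compound 3 have no readable size, and compound 3 stands at the limit together with the other two.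

Compound 4 `Cc1ccc(Oc2ccc(C(=O)NCCCN(C)C)cc2)cc1` differs from compound 3 by 2-(dimethylamino)ethyl in place of hydrogen on a saturated chain carbon bound to an amide-type nitrogen. Going by the values given here, no measured step bears on this change with a readable size, so no direction beyond the scatter is indicated. Compound 4 is expected at 1000 h, between 300 h and 3000 h. The expected step is a number no higher from compound 3 to compound 4 (the limit leaves the size open), most likely reported only as a limit.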

Compound 4, half-life: > 1000 h
Compound 4 ended at the assay's limit; the forecaster's own chance of this, stated with the estimate: 80%; the middle value sits exactly at the limit.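

No step from compound 1, compound 2 or compound 3 to compound 4 can be read, since all four values are limits: the limit of > 1000 h in this assay, at which 4 of the 4 values shown sit.

The compounds shown leave open whether these amide nitrogen substituents differ in half-life at all.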